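The compounds below may be only part of what the source reports. "The series", "measured", "known", "first", "only" and "open" are said of these compounds alone.

Compound 1 `COc1ccc2ncc(-c3nn[nH]n3)cc2c1`: in a functional assay on the whole organism (strain Sprague-Dawley) for inhibition, with Rattus norvegicus as the target (on this read-out lower numbers stand for an effect already at smaller amounts and higher numbers for an effect only at larger amounts of compound), compound 1 gives > 25 mg/kg, which is a limit of the assay and not a number.
Compound 2 `c1ccc2ncc(-c3nn[nH]n3)cc2c1`: compound 2 gives 25 mg/kg.
Compound 3 `c1nc2ccc(C3CCCCC3)cc2cc1-c1nn[nH]n1`: compound 3 gives > 25 mg/kg, again a limit of the assay.

Compound 2 thus stands as the only number shown; the two other values are limits (the limit of > 25 mg/kg in this assay, at which 2 of the 3 values shown sit). Compound 4 `Cc1cccc2cc(-c3nn[nH]n3)cnc12` differs from compound 2 by methyl in place of hydrogen on an aromatic carbon. The measured steps that bear on this change, a group entering or leaving an aromatic carbon of the shared core, are a number no higher from compound 1 to compound 2 (the limit leaves the size open) and a number no lower from compound 2 to compound 3 (the limit leaves the size open). Both are left unreadable in size by the limits, so they give no direction and no size to expect beyond the scatter. The expected step is therefore no change at the digits printed from compound 2 to compound 4 (within the scatter). The estimate for compound 4 is 25 mg/kg, with a range from 10 mg/kg to 60 mg/kg.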

Compound 4, minimum effective dose: 25 mg/kg
Compound 4: middle estimate and measured number agree at the digits printed, and the stated range covers the measured number.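

Methyl in place of hydrogen on this aromatic carbon, ortho to a fused ring, gives no change at the digits printed from compound 2 to compound 4 (within the scatter) in this assay. Among the compounds shown here, this is the only step here whose size can be read, and it shows that a single added carbon at this place leaves the minimum effective dose where it was. The other steps, which involve compound 1 and compound 3, cannot be read: the limit of > 25 mg/kg in this assay, at which 2 of the 4 values shown sit.

Going by these compounds, whether an amine, a carboxylic acid or a longer chain at this place would also leave the dose unchanged stays open. A single methyl cannot show whether a group that lowers the dose exists.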